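The source may hold more compounds than are shown below. What is called first, only, known or untested is meant among the compounds shown, and "the series" means these compounds.

Measured compounds:
Compound 1, `O=C(O)c1csc([C@H]2CC[C@@H]3[C@@H](COc4ccccc4)[C@H](O)C[C@@H]3O2)n1`. In a functional assay on CHO cells for agonist activity at prostaglandin E2 receptor EP3 subtype (Homo sapiens), read by fluorescence and calcium flux (a lower number here means that less compound is needed, a higher number that more compound is needed for the effect), compound 1 gives > 10000 nM, which is a limit of the assay rather than a number.
Compound 2, `O=C(O)c1csc([C@H]2CC[C@@H]3[C@@H](CCCOc4ccccc4)[C@H](O)C[C@@H]3O2)n1`. In this assay compound 2 gives 5800 nM.

Compound 2 thus holds the only number shown in this assay; the other value is a limit. Among the measured compounds shown here, the one step measured, an at least 1.7-fold lower number from compound 1 to compound 2 (0.23 log units; that floor lies within the scatter), is the step from phenoxy to 2-phenoxyethyl on a saturated chain carbon bound to a saturated ring carbon; its size is only a floor, set by the limit of > 10000 nM in this assay, at which 1 of the 2 values shown sits.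

Compound 3, `O=C(O)c1csc([C@H]2CC[C@@H]3[C@@H](CCOc4ccccc4)[C@H](O)C[C@@H]3O2)n1`, is not yet measured. It differs from compound 2 by phenoxy in place of phenoxymethyl on a saturated chain carbon, two bonds along the chain from a saturated ring carbon, so its chain is one carbon shorter than in compound 2 and one longer than in compound 1. For the measured compounds named here, only the step from compound 1 to compound 2 bears on it, and it fixes no more than a floor, so the expected step of a 1.4-fold higher number from compound 2 to compound 3 (0.14 log units; within the scatter) is a modest rise that may not clear the scatter. Compound 3 is estimated at 8000 nM, within 3000 nM to 20000 nM.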

Compound 3, half-maximal effective concentration: 1400 nM
Beside the measured number, compound 3's estimate is 5.7-fold (0.76 log units) above it; measured number outside the range, below it.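

In this assay, phenoxy in place of phenoxymethyl at this position, on a saturated chain carbon two bonds along the chain from a saturated ring carbon, gives a 4.1-fold lower number from compound 2 to compound 3 (0.62 log units; beyond the scatter), so the shorter chain here lowers the number rather than raising it. Chain length therefore does not act in one direction across these three compounds: the intermediate chain carries the lowest number, and both the longer and the shorter chain sit higher. Shortening the chain further reverses the gain, as the other new step is an at least 7.1-fold lower number from compound 1 to compound 3 (0.85 log units; beyond the scatter), and its size is only a floor: the limit of > 10000 nM in this assay, at which 1 of the 3 values shown sits.

From the compounds shown here alone, how far the shortest chain actually lies from the others remains open. So does whether a fluorine or an amine on the aromatic ring, or a thioether in place of the ether oxygen, would move the number further at the intermediate chain length.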